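Cytotoxicity notes on a thiazolylidene hydrazide series

The compounds below may be only part of what the source reports. "The series", "measured", "known", "first", "only" and "open" are said of these compounds alone.

Measured compounds:
compound 1 `Cc1nnc(SCC(=O)N/N=c2/scc(-c3ccc(F)cc3)n2-c2ccccc2)s1` — in a functional assay on C6 cells (Rattus norvegicus) for cytotoxicity, read by MTT assay, with a stated time of 24 h, tested at 6 ug/mL (on this read-out higher numbers stand for a weaker effect at the one concentration tested and lower numbers for a stronger effect), compound 1 gives 74.3%
compound 2 `O=C(CSc1nnnn1-c1ccccc1)N/N=c1/scc(-c2ccc(F)cc2)n1-c1ccccc1` — in this assay compound 2 gives 74.9%
compound 3 `O=C(CSc1ncccn1)N/N=c1/scc(-c2ccc(F)cc2)n1-c1ccccc1` — in this assay compound 3 gives 84%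

Compound 1 carries the lowest of the three numbers, yet the steps of a number 0.6 percentage points higher from compound 1 to compound 2 (within the scatter) and a number 9.7 percentage points higher from compound 1 to compound 3 (within the scatter) lie within the scatter, as does a number 9.1 percentage points higher from compound 2 to compound 3 (within the scatter); the three compounds cannot be separated on these data.

Compound 4 `Cc1ccc(-c2cs/c(=N/NC(=O)CSc3nnc(C)s3)n2-c2ccccc2)cc1` differs from compound 1 by methyl in place of fluoro on an aromatic carbon. Among the compounds with values here, none of the measured steps touches this position; all three exchange the group on the sulfur, and none moves the number beyond the scatter. Nothing measured therefore points to a change beyond the scatter in this assay for compound 4. Compound 4 is expected to give 76%, with a range from 60% to 92%. For compound 4 the expected step is a number 1.7 percentage points higher from compound 1 to compound 4 (within the scatter).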

Compound 4, a percentage reported as activity, at one concentration (the size of the read-out at that concentration, not a potency): 65.9%
Beside the measured number, compound 4's estimate is 10.1 percentage points above it; the measured number falls inside the stated range.
By their numbers in this assay, from the lowest: compounds 4, 1, 2 and 3 (each within the scatter of the next, the first and the last beyond it).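

In this assay, within the data shown here, the exchange of 4-fluorophenyl to 4-methylphenyl gives a number 8.4 percentage points lower from compound 1 to compound 4 (within the scatter) and is the first measured change away from the group on the sulfur. For this one exchange, the position on the aromatic carbon therefore shows no step beyond the scatter. No supporting measurement bears on this result.

Going by these compounds, whether an amine or a carboxylic acid on this aromatic carbon would move the number beyond the scatter remains open. Also open, on these data alone, is whether methyl in place of fluoro gives a similar step with pyrimidin-2-yl or 1-phenyl-1H-tetrazol-5-yl on the sulfur.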